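Plasma Exposure in Monkeys After One Structural Swap

The source may report more compounds than this note shows. Statements on the series, on what has been measured and on what is new or still open speak of the compounds shown alone.

Of the compounds shown here, three that share a common core have been measured in an ADME assay on the whole organism (plasma) for pharmacokinetics, with Rhesus monkey (Macaca mulatta) as the target, read by LC-MS, at a dose of 1 mg/kg by the oral route; a lower number here means less compound in the circulation, a higher number more compound in the circulation at the dose given. Compound 1 `COc1ccc2nc(COc3ccc(CC4SC(=O)N([C@@H]5O[C@H](C(=O)O)[C@@H](O)[C@H](O)[C@H]5O)C4=O)cc3)n(C)c2c1` gives 892 ng.h/mL, compound 2 `O=C1NC(=O)C(Cc2ccc(OCc3nc4ccc(O)cc4[nH]3)cc2)S1` gives 85.4 ng.h/mL, and compound 3 `COc1ccc2nc(COc3ccc(CC(C(N)=O)[S+](C)[O-])cc3)n(C)c2c1` gives 36.7 ng.h/mL. Compound 3 therefore stands lowest of the three: its nearest neighbour is compound 2, whose number lies higher by a margin beyond the usual scatter, and compound 1 lies much further above it.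

Compound 4 `COc1ccc2nc(COc3ccc(CC(SC)C(=O)O)cc3)n(C)c2c1` has not yet been measured in this assay. It differs from compound 3 in a single place, described as follows: a group of 6 heavy atoms (3 carbon, 2 oxygen, 1 sulfur; no ring) in place of a group of 7 heavy atoms (3 carbon, 1 nitrogen, 2 oxygen, 1 sulfur; no ring), on a saturated chain carbon bound to an aromatic carbon.

Among the measured compounds shown here, no two measured compounds differ from each other in only one place, so there is no measured step of this kind to lean on, and the spread among the three compounds is wide. Since compound 3 gives 36.7 ng.h/mL, the lowest number in the set, an upward move seems more likely than a further fall, though a result within the scatter of compound 3 cannot be ruled out. Compound 4 is expected to give 100 ng.h/mL, with a likely range from 25 ng.h/mL to 400 ng.h/mL. This corresponds to an expected step of a 2.7-fold higher number from compound 3 to compound 4 (0.44 log units; beyond the scatter), a modest rise that may or may not clear the scatter.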

Compound 4, area under the concentration-time curve: 76.8 ng.h/mL
Compound 4: middle estimate off by 1.3-fold (0.11 log units), on the high side, and the stated range covers the measured number.
By their numbers in this assay, from the lowest: compound 3; then compounds 4 and 2 (each within the scatter of the next); then compound 1.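

In this assay, among the compounds shown here, the single change at this place gives a 2.1-fold higher number from compound 3 to compound 4 (0.32 log units; beyond the scatter) and so is the first step in the set that can be read on its own. It shows that, on a saturated chain carbon bound to an aromatic carbon, exchanging one group for another can move the number beyond the usual scatter, though the step is only modest. The two groups have the same hydrogen-bond donor and acceptor counts and neither carries a net charge, so those counts do not tell compound 3 and compound 4 apart, and no measurement shown here explains the rise.

The change alters the sulfur-bearing part and the carbonyl-bearing part of the group at once, so the compounds shown leave open which of the two goes with the step. They also leave open how the number would respond at this place to an amine, to a methyl ester in place of the carboxylic acid, or to a longer chain in place of the methylsulfanyl part.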